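The compounds below may be only part of what the source reports. "The series", "measured", "known", "first", "only" and "open" are said of these compounds alone.

Of the compounds shown here, two sharing one core have been measured so far. Going by the values given here, in a functional assay on HeLa cells (Homo sapiens) for antiproliferative activity, read by CCK-8 assay, with a stated time of 72 h (a lower number here means a stronger inhibitor, a higher number a weaker inhibitor), compound 1 `O=C(Nc1cccc(-c2oc3cc(-c4ccc(F)cc4)ccc3c(=O)c2O)c1)c1ccccc1F` gives 5630 nM, and compound 2 `O=C(Nc1cccc(-c2oc3cc(-c4ccc(F)cc4)ccc3c(=O)c2O)c1)c1ccc(F)cc1F` gives 10700 nM; these two numbers sit close together, since the only known step, a 1.9-fold higher number from compound 1 to compound 2 (0.28 log units; within the scatter), lies within the scatter. Compound 3 `O=C(Nc1cccc(-c2oc3cc(-c4ccc(F)cc4)ccc3c(=O)c2O)c1)c1ccc(Br)cc1` differs from compound 2 by 4-bromophenyl in place of 2,4-difluorophenyl on a carbonyl carbon. Among the compounds with values here, no measured step tests this kind of change directly, and the one step known was small, so no shift beyond the scatter is expected. Compound 3 is therefore estimated at 7000 nM, within 2500 nM to 20000 nM, an expected step of a 1.5-fold lower number from compound 2 to compound 3 (0.18 log units; within the scatter).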

Compound 3, half-maximal inhibitory concentration: 9740 nM
For compound 3 the middle estimate is 1.4-fold (0.14 log units) below the measured one, within the range that was stated.
By their numbers in this assay, from the lowest: compounds 1, 3 and 2 (each within the scatter of the next).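

In this assay, the group on the carbonyl carbon tolerates a bromine as well as fluorine: 4-bromophenyl in place of 2,4-difluorophenyl changes little (a 1.1-fold lower number from compound 2 to compound 3 (0.04 log units; within the scatter)), and the same holds for 4-bromophenyl in place of 2-fluorophenyl (a 1.7-fold higher number from compound 1 to compound 3 (0.24 log units; within the scatter)). All three compounds therefore stand level with one another. No evidence is available to explain this flat result. Going by these compounds, whether an amine, a carboxylic acid or a longer chain in place of this phenyl ring would move the number beyond the scatter stays open.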